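The source may hold more compounds than are shown below. What is called first, only, known or untested is meant among the compounds shown, and "the series" means these compounds.

Measured compounds, in a functional assay on MCF7 cells (Homo sapiens) for cytotoxicity, read by MTT assay, with a stated time of 72 h; on this read-out higher numbers stand for weaker inhibition and lower numbers for stronger inhibition:

Compound 1 `N/C(=N\NC(=S)N1CCOCC1)c1ccccn1` gives 4700 nM.
Compound 2 `Cc1ccnc(/C(N)=N/NC(=S)N2CCOCC2)c1` reaches only the assay limit of > 100000 nM, which is a limit and not a number.
Compound 3 `N/C(=N\NC(=S)N1CCCC1)c1ccc(F)cn1` gives 900 nM.

Among the two numbers that are not limits, compound 1 stands highest; the nearest is compound 3, which lies below it beyond the usual scatter. For the measured compounds named here, the one measured step that starts from compound 1 is an at least 21-fold higher number from compound 1 to compound 2 (1.32 log units; beyond the scatter), a change on the aromatic ring of the core that pushed the read-out to the assay limit (the limit of > 100000 nM in this assay, at which 1 of the 3 values shown sits).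

Compound 4 `N/C(=N\NC(=S)N1CCSCC1)c1ccccn1` is not yet measured. It differs from compound 1 by thiomorpholin-4-yl in place of morpholin-4-yl on a thiocarbonyl carbon. Going by the values given here, no measured step touches this part of the molecule: the only measured step concerns the aromatic ring, not the group on the thiocarbonyl carbon, so nothing among the measured compounds points one way or the other. The expectation for compound 4 is therefore a step of about a 1.2-fold lower number from compound 1 to compound 4 (0.07 log units; within the scatter), that is, no change beyond the scatter. Compound 4 is estimated at 4000 nM in this assay, with a plausible range from 1500 nM to 12000 nM.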

Compound 4, half-maximal inhibitory concentration: 8800 nM
Beside the measured number, compound 4's estimate is 2.2-fold (0.34 log units) below it; low and high end bracket the measured number.
By their numbers in this assay, from the lowest: compound 3; then compounds 1 and 4 (each within the scatter of the next). At a limit, above all of these: compound 2.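

For the compounds shown here, the earlier compounds gave a measured step only on the aromatic ring of the core, so this is the first look at the group on the thiocarbonyl carbon. In this assay, thiomorpholin-4-yl in place of morpholin-4-yl gives a 1.9-fold higher number from compound 1 to compound 4 (0.27 log units; within the scatter). Exchanging the oxygen of this six-membered ring for sulfur therefore produces no difference that can be told apart from the spread of repeated measurements, and no available evidence bears on this result.

This single exchange says little about how much freedom the position allows, since both groups are six-membered rings of the same size. An open-chain amine such as dimethylamino, or a piperazin-1-yl ring, on the same thiocarbonyl carbon of the core of compound 1 remains an open test.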